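This account rests on a few compounds, and the source may have more. Where it says the series, first, only, none or still open, it means among the compounds named here.

In a functional assay on HepG2 cells (Homo sapiens) for cytotoxicity, read by MTT assay (on this read-out higher numbers stand for weaker inhibition and lower numbers for stronger inhibition), compound 1 `COc1ccc(/C=C/C(=O)c2ccc(OC)c3c2OC(C)(C)C=C3)cc1O` gives 450 nM and compound 2 `COc1ccc(/C=C/C(=O)c2ccc(OC)c3c2OC(C)(C)C=C3)cc1OC(=O)CCl` gives 120 nM, the lower of the two numbers and so the stronger inhibition of the pair. Compound 3 `COc1ccc(/C=C/C(=O)Oc2cc(/C=C/C(=O)c3ccc(OC)c4c3OC(C)(C)C=C4)ccc2OC)cc1` keeps the carbonyl of compound 2 but changes what it carries, with 2-(4-methoxyphenyl)ethenyl in place of chloromethyl on a carbonyl carbon. For the measured compounds named here, only one measured step bears on this change. It is a 3.8-fold lower number from compound 1 to compound 2 (0.57 log units; beyond the scatter), a modest step seen when (chloromethyl)carbonyl replaced hydrogen on an oxygen on an aromatic ring. Going by the values given here, compound 3 also has a carbonyl group on that oxygen, but no measured compound yet carries the larger group, so the evidence is thin. The expected change is a 2.0-fold higher number from compound 2 to compound 3 (0.30 log units; within the scatter), a small rise in the number. For compound 3 the estimated value is 240 nM, with an expected range of 70 nM to 800 nM.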

Compound 3, half-maximal inhibitory concentration: 430 nM
Beside the measured number, compound 3's estimate is 1.8-fold (0.25 log units) below it; low and high end bracket the measured number.
By their numbers in this assay, from the lowest: compound 2; then compounds 3 and 1 (each within the scatter of the next).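

On the carbonyl carbon, what the carbonyl carries clearly matters: in this assay, the larger 2-(4-methoxyphenyl)ethenyl in place of chloromethyl gives a 3.6-fold higher number from compound 2 to compound 3 (0.55 log units; beyond the scatter), so the lower number of compound 2 does not follow from just any carbonyl group on that oxygen. Placing (2-(4-methoxyphenyl)ethenyl)carbonyl instead of hydrogen on the oxygen gives a 1.0-fold lower number from compound 1 to compound 3 (0.02 log units; within the scatter), a step that cannot be told apart from no difference, so among the groups shown only (chloromethyl)carbonyl stands apart. No measurement shown explains why these two carbonyl groups differ.

On these data alone, whether the chlorine itself is needed remains open, and plain methyl or bromomethyl on the same carbonyl carbon would address that. How an aminomethyl group or a longer chain such as 3-chloropropyl would compare there is also unknown.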